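The compounds below may be only part of what the source reports. "The series", "measured", "known", "first", "only" and "open" are said of these compounds alone.

Compound 2 `Cc1ccc2oc(CSc3nnc(C)s3)cc(=O)c2c1` gives only a limit in a functional assay on MDA-MB-435S cells (Homo sapiens) for cytotoxicity, read by MTT assay, with a stated time of 72 h; on this read-out higher numbers stand for weaker inhibition and lower numbers for stronger inhibition: for compound 2 the read-out is > 25000 nM, a limit and not a number. Compound 1 `Cc1nnc(SCc2cc(=O)c3cc(Cl)ccc3o2)o1` likewise returns only a limit, > 25000 nM. Compound 3 `Cc1nnc(SCc2cc(=O)c3cc(Cl)ccc3o2)s1` also returns only a limit, > 25000 nM. Compound 4 `Cc1ccc2oc(CSc3nnc(C)o3)cc(=O)c2c1` carries 5-methyl-1,3,4-oxadiazol-2-yl in place of 5-methyl-1,3,4-thiadiazol-2-yl on a sulfur. The same exchange of the five-membered ring, run from compound 1 to compound 3, gives a step that the two limits leave unreadable from compound 1 to compound 3, and the other measured step, a step that the two limits leave unreadable from compound 2 to compound 3, is equally unreadable, because of the limit of > 25000 nM in this assay, at which 3 of the 3 values shown sit. Within the data shown here, no measured step therefore supplies a size or a direction for the change to compound 4. Compound 4 is expected to stay around the same limit, estimated at 30000 nM with a range from 10000 nM to 100000 nM. The expected step from compound 2 to compound 4 is a step that the limit leaves unreadable from compound 2 to compound 4, nothing beyond the scatter.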

Compound 4, half-maximal inhibitory concentration: > 25000 nM
Compound 4: no number, only a limit (the forecaster's own chance of this, stated with the estimate: 85%); the middle value does not contradict the limit.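

Neither the step from compound 2 to compound 4 nor the one from compound 1 to compound 4 can be read, because these values are limits and not numbers: the limit of > 25000 nM in this assay, at which 4 of the 4 values shown sit.

The compounds shown leave open whether exchanging the five-membered ring, or chloro and methyl, changes the read-out at all.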